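Dimethyl groups on the phenyl ring of compound 3

A few compounds are considered here, and "the series" means these few. Any claim that something is new, unique, unknown or untested is made for them only; others in the source may bear on it.

In an assay on isolated protein for inhibition of Dihydrofolate reductase (Homo sapiens), read by spectrophotometry, using NADPH, with stated times of 5 s and 6 min, tested at 5 uM (on this read-out lower numbers stand for a weaker effect and higher numbers for a stronger effect at the one concentration tested), the measured compounds stand as follows.
Compound 1, `NC1=NC2(CCOCC2)N(OCCCOc2ccccc2Br)C(N)=N1`, gives 83.8%.
Compound 2, `NC1=NC2(CCOCC2)N(OCCCOc2ccc(Cl)cc2Cl)C(N)=N1`, gives > 90%, which is a limit of the assay and not a number.
Compound 3, `NC1=NC2(CCOCC2)N(OCCCOc2ccccc2)C(N)=N1`, gives > 90%, which is a limit of the assay and not a number.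

Compound 3 thus sits at the top limit, as does compound 2, a point noted in the limit of > 90% in this assay, at which 2 of the 3 values shown sit. The step of a number at least 6.2 percentage points higher from compound 1 to compound 3 (that floor lies within the scatter) has a floor within the scatter, and the step that the two limits leave unreadable from compound 2 to compound 3 cannot be read because both ends are limits. The step of a number at least 6.2 percentage points higher from compound 1 to compound 2 (that floor lies within the scatter) also has a floor within the scatter.

Compound 4, `Cc1cc(C)cc(OCCCON2C(N)=NC(N)=NC23CCOCC3)c1`, is not yet measured. It differs from compound 3 by 3,5-dimethylphenyl in place of phenyl on an oxygen on a saturated carbon. The measured steps all change the same aryl group and every one leaves the compounds near or at the limit, with no step shown beyond the scatter. A step of a number no higher from compound 3 to compound 4 (the limit leaves the size open) is therefore expected, that is none beyond the scatter. In this assay compound 4 is expected to give about 90%, with a range from 78% to 98%.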

Compound 4, a percentage reported as inhibition, at one concentration (the size of the read-out at that concentration, not a potency): 84.3%
The estimate for compound 4 lay 5.7 percentage points above the measured number; the measured number falls inside the stated range.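

In this assay, the change to 3,5-dimethylphenyl gives a number at least 5.7 percentage points lower from compound 3 to compound 4 (that floor lies within the scatter) and a number at least 5.7 percentage points lower from compound 2 to compound 4 (that floor lies within the scatter), so neither step is shown to go beyond the scatter, and their true sizes stay open: the limit of > 90% in this assay, at which 2 of the 4 values shown sit. Set against the 2-bromophenyl group, it gives a number 0.5 percentage points higher from compound 1 to compound 4 (within the scatter), so these two different rings cannot be told apart on this read-out. This position on the oxygen therefore carries two methyl groups as well as halogens, with no loss shown beyond the scatter.

The step between the two compounds at the limit still cannot be read. From the compounds shown here alone, it also remains open whether an amine or a carboxylic acid on the phenyl ring, or a longer chain in place of the saturated chain, would give a number clearly apart from these.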